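The source may hold more compounds than are shown below. What is called first, only, known or untested is meant among the compounds shown, and "the series" means these compounds.

Measured compounds in an ADME assay on Huh-7 cells (Homo sapiens) for cytotoxicity, with a stated time of 72 h; a lower number here means that less compound is tolerated, a higher number that more compound is tolerated:
- compound 1, `CC(C)(C)CCN1C(=O)C(C2=NS(=O)(=O)c3cc(NS(C)(=O)=O)ccc3N2)=C(O)C2CCCCCCC21`: for compound 1 the entry reads "not determined" (no result reported), so no result exists for compound 1 in this assay.
- compound 2, `CS(=O)(=O)Nc1ccc2c(c1)S(=O)(=O)N=C(C1=C(O)C3CCCC3N(CCC3CC3)C1=O)N2`: compound 2 gives > 33000 nM, a limit of the assay rather than a number.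
- compound 3, `CC(C)(C)CCN1C(=O)C(C2=NS(=O)(=O)c3cc(NS(C)(=O)=O)ccc3N2)=C(O)C2CCCCC21`: compound 3 gives > 33000 nM, again a limit of the assay.

Compound 3 therefore stands at a limit, not at a measured number; one further value, that of compound 2, is also a limit, and for compound 1 no number exists at all. What the series shows so far is the limit of > 33000 nM in this assay, at which 2 of the 3 values shown sit. Among the compounds with values here, no two measured compounds differ in a single place, so no measured step in this assay is available to calibrate from.

Compound 4, `CS(=O)(=O)Nc1ccc2c(c1)S(=O)(=O)N=C(C1=C(O)C3CCCCC3N(C3CCCCC3)C1=O)N2`, is the next compound to be measured. It differs from compound 3 by cyclohexyl in place of 3,3-dimethylbutyl on an amide-type nitrogen in a ring; in words, cyclohexyl in place of 3,3-dimethylbutyl on an amide-type nitrogen in a ring. Within the data shown here, with compound 3 sitting at a limit and no measured step to lean on, the expectation for the move from compound 3 to compound 4 is a number no higher from compound 3 to compound 4 (the limit leaves the size open), that is, nothing beyond the scatter. Compound 4 is accordingly estimated at 33000 nM, in a range from 12000 nM to 70000 nM, and most likely the assay will again report only a limit for compound 4.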

Compound 4, half-maximal cytotoxic concentration: > 33000 nM
Compound 4 ended at the assay's limit (the forecaster's own chance of this, stated with the estimate: 75%); the middle value sits exactly at the limit.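

Compound 3 gives > 33000 nM, a limit of the assay. Within the data shown here, compound 4 gives > 33000 nM, again a limit, so no step from compound 3 to compound 4 can be read. The compounds shown leave open at what concentration, if any, either compound reaches a measurable half-maximal cytotoxic concentration.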